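This account rests on a few compounds, and the source may have more. Where it says the series, first, only, none or still open, it means among the compounds named here.

Compound 1 `O=C(NO)c1ccc(-c2cn([C@@H]3C[C@@H](C(=O)O)N(Cc4ccccc4)C3)nn2)cc1`: in an assay on Sf9 cells for inhibition of histone deacetylase 11 (Homo sapiens), read by fluorescence, tested at 0.5 uM (on this read-out lower numbers stand for less inhibition and higher numbers for more inhibition at the one concentration tested (going by the name of the read-out)), compound 1 gives < 10%, a limit of this assay.
Compound 2 `O=C(NO)c1ccc(-c2cn([C@H]3C[C@H](C(=O)O)N(CCCc4ccccc4)C3)nn2)cc1`: compound 2 gives < 10%, also a limit.
Compound 3 `O=C(/C=C/c1cn([C@@H]2C[C@H](CO)N(CCCc3ccccc3)C2)nn1)NO`: compound 3 gives 12%.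

Compound 3 is thus the only one of the three with an actual number in this assay; the other two sit at a limit, as the limit of < 10% in this assay, at which 2 of the 3 values shown sit, shows. Compound 4 `O=C(NO)c1cccc(-c2cn([C@@H]3C[C@H](CO)N(CCCc4ccccc4)C3)nn2)c1` has not yet been measured. It differs from compound 3 in one place: 3-(hydroxycarbamoyl)phenyl in place of 2-(hydroxycarbamoyl)ethenyl on an aromatic carbon. Going by the values given here, no two measured compounds differ in a single place, so no measured step gives the size of this one. The expectation is a small shift in this assay, none beyond the scatter, with a real chance that only a limit comes back. Compound 4 is estimated at 10%, within 0% to 25%, meaning an expected step of a number 2 percentage points lower from compound 3 to compound 4 (within the scatter).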

Compound 4, a percentage reported as inhibition, at one concentration (the size of the read-out at that concentration, not a potency): < 10%
Compound 4: no number, only a limit; the forecaster's own chance of this, stated with the estimate: 50%; the middle value lies on the limit itself.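

Going by these compounds alone, putting 3-(hydroxycarbamoyl)phenyl in place of 2-(hydroxycarbamoyl)ethenyl gives the first single-place comparison in this assay, with a number at least 2 percentage points lower from compound 3 to compound 4 (that floor lies within the scatter). Going by these compounds, the value of compound 4 is a limit, so this step has only a floor and its true size stays unknown. This change on the aromatic carbon therefore brings no shift that can be told from the scatter, and the series stays close to the limit: the limit of < 10% in this assay, at which 3 of the 4 values shown sit.

On these data alone, what a longer chain carrying the hydroxycarbamoyl group would do on this carbon remains open. So does whether any group here can lift inhibition clear of that limit.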